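Swapping a Hydroxy Tail for a Methanesulfonamide

A few compounds are considered here, and "the series" means these few. Any claim that something is new, unique, unknown or untested is made for them only; others in the source may bear on it.

Compound 1 `Cn1ncc(Cl)c1-c1cc(C(=O)N[C@@H]2CN[C@H](CCO)C[C@H]2c2ccc(F)c(F)c2)oc1Cl` and compound 2 `Cn1ncc(Cl)c1-c1cc(C(=O)N[C@@H]2CN[C@H](CCO)C[C@H]2c2ccc(Cl)c(Cl)c2)oc1Cl` share one core and differ only in the aryl group attached to the saturated ring. In a functional assay on HCT-116 cells (Homo sapiens) for antiproliferative activity, read by sulforhodamine B assay, with a stated time of 72 h (on this read-out higher numbers stand for weaker inhibition and lower numbers for stronger inhibition), compound 1 gives 360 nM, and compound 2 gives 340 nM. Among the measured compounds shown here, the step of a 1.1-fold lower number from compound 1 to compound 2 (0.02 log units; within the scatter) is within the scatter, so the two numbers cannot be told apart; compound 1 sits in the same band as the only other measured compound. Compound 3 `Cn1ncc(Cl)c1-c1cc(C(=O)N[C@@H]2CN[C@H](CCNS(C)(=O)=O)C[C@H]2c2ccc(F)c(F)c2)oc1Cl` has not yet been measured. It differs from compound 1 in methanesulfonamido in place of hydroxy on a saturated chain carbon, two bonds along the chain from a saturated ring carbon. For the measured compounds named here, the single measured step concerns a different place and a different kind of change, so no measured step bears directly on this one. With nothing to point in either direction, compound 3 is expected to stay close to compound 1, with an expected step of no change at the digits printed from compound 1 to compound 3 (within the scatter) that remains within the scatter. The estimate for compound 3 in this assay is 360 nM, with a range from 150 nM to 900 nM.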

Compound 3, half-maximal inhibitory concentration: 920 nM
For compound 3 the middle estimate is 2.6-fold (0.41 log units) below the measured one, outside the stated range (above it).
By their numbers in this assay, from the lowest: compounds 2 and 1 (each within the scatter of the next); then compound 3.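

Among the compounds shown here, this is the first measured change on the chain, and it shows that this position is not indifferent to what sits at its end: in this assay, methanesulfonamido in place of hydroxy gives a 2.6-fold higher number from compound 1 to compound 3 (0.41 log units; beyond the scatter), a modest step towards weaker inhibition. The aryl swap between compound 1 and compound 2 stayed within the scatter and touched a different place, so it could not reveal this, and the new result adds that the larger group lowers activity without abolishing it. No measured evidence here explains the step.

Going by these compounds, how an amine, a carboxylic acid or a longer chain would compare at this place remains open. Also open, on these data alone, is whether 3,4-dichlorophenyl would again match 3,4-difluorophenyl when combined with the 2-(methanesulfonamido)ethyl tail.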